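Moving fluorine from 4-fluorobenzyl to 2-fluorobenzyl

The source may report more compounds than this note shows. Statements on the series, on what has been measured and on what is new or still open speak of the compounds shown alone.

Compound 1 `C=C1C(=O)O[C@H]2[C@H]1CC/C(COC(=O)CCC(=O)NCCCCCCNC(=O)Cn1cc(F)c(=O)[nH]c1=O)=C\CC[C@@]1(C)O[C@@H]21`: > 20000 nM (a limit)
Compound 2 `C=C1C(=O)O[C@H]2[C@H]1CC/C(COC(=O)CCC(=O)N1CCN(C(=O)Cn3cc(F)c(=O)[nH]c3=O)CC1)=C\CC[C@@]1(C)O[C@@H]21`: > 20000 nM (a limit)
Compound 3 `C=C1C(=O)O[C@H]2[C@H]1CC/C(COC(=O)Cn1cc(F)c(=O)n(Cc3ccc(F)cc3)c1=O)=C\CC[C@@]1(C)O[C@@H]21`: 1140 nM (a number)

All three compounds were tested in a functional assay on Bel7402/5-FU cells (Homo sapiens) for antiproliferative activity, read by MTT assay, with a stated time of 72 h (a higher number here means a weaker inhibitor, a lower number a stronger inhibitor), and two of them returned no number. Compound 1 is recorded only as the limit > 20000 nM in this read-out. Compound 2 is likewise recorded only as the limit > 20000 nM in this read-out. Compound 3 alone gives a number, and its 1140 nM is the only fixed point in the set.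

Compound 4 `C=C1C(=O)O[C@H]2[C@H]1CC/C(COC(=O)Cn1cc(F)c(=O)n(Cc3ccccc3F)c1=O)=C\CC[C@@]1(C)O[C@@H]21` has not yet been measured. It differs from compound 3 in one place: 2-fluorophenyl in place of 4-fluorophenyl on a saturated chain carbon bound to an aromatic nitrogen with 2-fluorophenyl in place of 4-fluorophenyl on a saturated chain carbon bound to an aromatic nitrogen. The two have the same atoms, joined differently.

Among the measured compounds shown here, no measured pair shows what such a change does, so the expectation starts from compound 3 and its 1140 nM as the anchor. The expected change is a 1.1-fold higher number from compound 3 to compound 4 (0.06 log units; within the scatter) and it is estimated to stay within the usual scatter, with no firm direction. In this assay the estimate for compound 4 is 1300 nM with 500 nM and 3500 nM as the expected ends of its range.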

Compound 4, half-maximal inhibitory concentration: 3830 nM
Compound 4: the middle estimate sits 2.9-fold (0.47 log units) below what was measured; measured number above the stated range.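

In this assay, among the compounds shown here, exchanging 4-fluorobenzyl for 2-fluorobenzyl gives a 3.4-fold higher number from compound 3 to compound 4 (0.53 log units; beyond the scatter) with the same atoms and the rest of the molecule unchanged, the only step in the set that can be read. It shows that this place, on a saturated chain carbon bound to an aromatic nitrogen, responds to where the fluorine sits on the phenyl ring, which compound 3 alone could not show, and that the 4-fluorobenzyl form is the stronger of the pair in this one comparison. Compound 4 nonetheless remains a measured number, like compound 3, and does not reach the limit of the assay, which is no number but the mark that compound 1 and compound 2 carry: the limit of > 20000 nM in this assay, at which 2 of the 4 values shown sit.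

The data give no cause for the step, and a single pair of isomers sets no trend for this position. From the compounds shown here alone, how an unsubstituted benzyl, a chlorobenzyl or a methoxybenzyl would read at this place stays open, as does whether the same shift of fluorine would have a similar effect on a different linker to the shared core.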